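The source may report more compounds than this note shows. Statements on the series, on what has been measured and on what is new or still open speak of the compounds shown alone.

Measured compounds:
compound 1, `COc1cc(-c2cc(/C=C/C(=O)c3ccc(N)cc3)[nH]n2)cc(OC)c1OC`, 95%
compound 2, `COc1ccc(-c2cc(/C=C/C(=O)c3ccc(N)cc3)[nH]n2)cc1OC`, 99%
compound 3, `COc1cc(C(=O)/C=C/c2cc(-c3cc(OC)c(OC)c(OC)c3)n[nH]2)cc(OC)c1OC`, 96%

All three were tested in a functional assay on SW-620 cells (Homo sapiens) for cytotoxicity, read by sulforhodamine B assay, with a stated time of 48 h, tested at 0.01 uM; on this read-out lower numbers stand for a stronger effect and higher numbers for a weaker effect at the one concentration tested. Compound 1 gives 95%, compound 2 gives 99% and compound 3 gives 96%, so all three leave the cells largely unaffected at this concentration, and the values lie within the scatter of one another.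

The change from compound 1 to compound 2 is hydrogen in place of methoxy on an aromatic carbon. It made a number 4 percentage points higher from compound 1 to compound 2 (within the scatter), a step that is within the scatter.

Compound 4, `COc1ccc(-c2cc(/C=C/C(=O)c3cc(OC)c(OC)c(OC)c3)[nH]n2)cc1OC`, is not yet measured. Among the compounds with values here, it arises from compound 3 by hydrogen in place of methoxy on an aromatic carbon, the same change as the one from compound 1 to compound 2, made at a place described in the same way. How the core of compound 3 differs from that of compound 1 is not broken down here.

Because the earlier step was a number 4 percentage points higher from compound 1 to compound 2 (within the scatter), the step from compound 3 to compound 4 in this assay is expected to be small as well, about a number 2 percentage points higher from compound 3 to compound 4 (within the scatter). Compound 4 is therefore estimated to give 98%, likely between 88% and 104%.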

Compound 4, a percentage reported as activity, at one concentration (the size of the read-out at that concentration, not a potency): 98%
Estimate against measurement, compound 4: no gap at the digits printed; measured number inside the range.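

In this assay, hydrogen in place of methoxy on an aromatic carbon gives a number 2 percentage points higher from compound 3 to compound 4 (within the scatter), and the two cases agree: the same change on two cores in this assay, a number 4 percentage points higher (within the scatter) from compound 1 to compound 2 and a number 2 percentage points higher (within the scatter) from compound 3 to compound 4, 2 percentage points apart, within the scatter of two such steps. On these two cores, then, the change carries over in the limited sense that neither step can be told apart from the scatter. This does not show that the change is without effect in general: all four compounds leave the cells largely unaffected at the one concentration tested, and a change that might alter the activity of a compound acting on the cells would not be seen in this read-out.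

The compounds shown leave open whether a different group on this aromatic carbon, such as a hydroxyl, a fluorine or a longer ethoxy chain, would shift the read-out of this assay. They also leave open how the change would behave on a further core, or at a concentration where these compounds clearly act on the cells.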